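A few compounds are considered here, and "the series" means these few. Any claim that something is new, unique, unknown or untested is made for them only; others in the source may bear on it.

Compound 1 `COc1ccc(C2N=C(SCc3cccc(Cl)c3)NC(C)=C2C(=O)Nc2ccc(F)cc2)cc1OC` was tested in a functional assay on the whole organism (artery, strain albino) with Rattus norvegicus as the target, with a stated time of 600 min, at a dose of 10 mg/kg by the oral route (on this read-out higher numbers stand for more inhibition at the one dose given (going by the name of the read-out) and lower numbers for less inhibition), where compound 1 gives 17.4%. Compound 2 `COc1ccc(C2N=C(SCc3ccc(Cl)cc3)NC(C)=C2C(=O)Nc2ccc(F)cc2)cc1OC` differs from it by 4-chlorophenyl in place of 3-chlorophenyl on a saturated chain carbon bound to a sulfur, and in this assay compound 2 gives 26.7%, a step of a number 9.3 percentage points higher from compound 1 to compound 2 (within the scatter). Compound 3 `COc1ccc(C2N=C(SCc3cccc(Cl)c3)NC(C)=C2C(=O)Nc2ccc(Br)cc2)cc1` rests on a different core; the difference between the two cores is not broken down here. In this assay compound 3 gives 32.8%. Compound 4 `COc1ccc(C2N=C(SCc3ccc(Cl)cc3)NC(C)=C2C(=O)Nc2ccc(Br)cc2)cc1` has not yet been measured and differs from compound 3 by 4-chlorophenyl in place of 3-chlorophenyl on a saturated chain carbon bound to a sulfur, at the same place and so the same change as that from compound 1 to compound 2. Because the earlier step of a number 9.3 percentage points higher from compound 1 to compound 2 (within the scatter) stayed within the scatter, a step of similar size is expected from compound 3 to compound 4, namely a number 7.2 percentage points higher from compound 3 to compound 4 (within the scatter). Compound 4 is therefore estimated to give 40% in this assay, expected to fall between 26% and 54%.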

Compound 4, a percentage reported as inhibition, in the whole organism at one dose (the size of the read-out at that dose, not a potency): 30.3%
Estimate against measurement, compound 4: 9.7 percentage points above, and the stated range covers the measured number.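

In this assay the change from 3-chlorobenzyl to 4-chlorobenzyl gives a number 2.5 percentage points lower from compound 3 to compound 4 (within the scatter), so on this second core, as on the first, the step stays within the scatter. Taken together, the two steps cannot be told apart: the same change on two cores in this assay, a number 9.3 percentage points higher (within the scatter) from compound 1 to compound 2 and a number 2.5 percentage points lower (within the scatter) from compound 3 to compound 4, 11.8 percentage points apart, within the scatter of two such steps. This shows that the change carries from one of these cores to the other without a step that stands out from the scatter, but it does not show that it has a real effect on either core, nor how it would behave on any other core.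

The compounds shown leave open what an amine or a carboxylic acid on that phenyl ring would do to the read-out. They also leave open the effect of a longer chain on the sulfur in place of the benzyl group.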